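Methoxy on a shared core: toxicity in hamster cells

A few compounds are considered here, and "the series" means these few. Any claim that something is new, unique, unknown or untested is made for them only; others in the source may bear on it.

Compound 1 `C/C(=N\NC(N)=S)c1ccc2[nH]c(-c3ccccc3)nc2c1`: 32000 nM
Compound 2 `COc1ccc(-c2nc3cc(/C(C)=N/NC(N)=S)ccc3[nH]2)cc1`: 13000 nM

In an ADME assay on BHK-21 cells (Mesocricetus auratus) for cytotoxicity, read by MTT assay (on this read-out lower numbers stand for higher toxicity in this test and higher numbers for lower toxicity in this test), compound 1 gives 32000 nM, and compound 2 gives 13000 nM. The change between them is methoxy in place of hydrogen on an aromatic carbon, and it made a 2.5-fold lower number from compound 1 to compound 2 (0.39 log units; beyond the scatter). For compound 3 `COc1ccc(-c2nc3cc(/C(C)=N/NC(N)=S)ccc3n2C2CCCCC2)cc1` the entry in this assay reads "not determined" (no result reported), so compound 3 has no reported number. Compound 4 `COc1ccc(-c2nc3cc(/C(C)=N/NC(N)=S)ccc3n2C2CCCCC2)c(OC)c1` differs from compound 3 by methoxy in place of hydrogen on an aromatic carbon. This is the same kind of change as from compound 1 to compound 2, but the place differs: there the methoxy sits para to a large group, here ortho to a large group and meta to a methoxy group. How the core of compound 3 differs from the core of compound 1 is not broken down here. Since compound 3 carries no number, the step from compound 3 to compound 4 cannot be measured against it; the expectation rests only on compound 2 with 13000 nM. For compound 4 a value near 10000 nM is expected, estimated to lie between 3000 nM and 40000 nM.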

Compound 4, half-maximal cytotoxic concentration: 17000 nM
Compound 4: the middle estimate sits 1.7-fold (0.23 log units) below what was measured; low and high end bracket the measured number.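

Compound 3 has no number to set against compound 4, so no new step can be read. Going by these compounds, what going from 4-methoxyphenyl to 2,4-dimethoxyphenyl does on this core stays open. No supporting data explain the value of compound 4.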